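Methyl on the Ring Nitrogen: Vero Cell Cytotoxicity

The source may hold more compounds than are shown below. What is called first, only, known or untested is meant among the compounds shown, and "the series" means these compounds.

Measured compounds:
Compound 1, `COc1cc(/C=C/c2nnc(-c3cc([N+](=O)[O-])cn3C)o2)ccc1O`, gives 203000 nM in an ADME assay on Vero cells (Chlorocebus sabaeus) for cytotoxicity, read by MTT assay, with a stated time of 72 h; a higher number here means a weaker inhibitor, a lower number a stronger inhibitor.
Compound 3, `COc1cc(/C=C/c2nnc(-c3cc([N+](=O)[O-])c[nH]3)o2)ccc1O`, gives 221000 nM in this assay.
Compound 2, `O=[N+]([O-])c1c[nH]c(-c2nnc(Cc3ccccc3F)o2)c1`, gives 620000 nM in this assay.

Compounds 1 and 3 share one core, while compound 2 is built on another; the difference between the two cores is not broken down here. Among the three, compound 2 gives the highest number. The change from compound 3 to compound 1 is methyl in place of hydrogen on an aromatic nitrogen, and it made a 1.1-fold lower number from compound 3 to compound 1 (0.04 log units; within the scatter).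

Compound 4, `Cn1cc([N+](=O)[O-])cc1-c1nnc(Cc2ccccc2F)o1`, has not yet been measured in this assay. It differs from compound 2 by methyl in place of hydrogen on an aromatic nitrogen, the same change at the same place. The step from compound 2 to compound 4 is therefore expected to be small, about a 1.1-fold lower number from compound 2 to compound 4 (0.04 log units; within the scatter). That expectation rests on a 1.1-fold lower number from compound 3 to compound 1 (0.04 log units; within the scatter), which stayed within the scatter. On this basis compound 4 is estimated at 560000 nM, with a likely range from 280000 nM to 1100000 nM.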

Compound 4, half-maximal inhibitory concentration: 245000 nM
For compound 4 the middle estimate is 2.3-fold (0.36 log units) above the measured one; the measured number lies below the stated range.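

In this assay, methyl in place of hydrogen on an aromatic nitrogen gives a 2.5-fold lower number from compound 2 to compound 4 (0.40 log units; beyond the scatter) on the core of compound 2, a modest step that lies beyond the usual scatter, while the same change on the core of compound 1 stayed within it. This does not show that the change has one fixed size on every core in this series, since two pairs of compounds are a thin basis for such a rule, and they give no cause for either step. It also does not show that the core alters the outcome, since the two steps cannot be told apart once the scatter of each is counted: the same change on two cores in this assay, a 1.1-fold lower number (0.04 log units; within the scatter) from compound 3 to compound 1 and a 2.5-fold lower number (0.40 log units; beyond the scatter) from compound 2 to compound 4, 2.3-fold (0.37 log units) apart, within the scatter of two such steps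

The compounds shown leave open whether the step would look the same on a third core. They also leave open what an ethyl group, a longer chain or a chain ending in an amine would do on that ring nitrogen in place of the methyl.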